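The compounds below may be only part of what the source reports. "The series", "measured", "known", "first", "only" and "open" are said of these compounds alone.

Compound 1 `CN1C/C(=C\c2cccc([N+](=O)[O-])c2)C(=O)/C(=C/c2ccccc2F)C1` sets the starting point: in a functional assay on THP-1 cells (Homo sapiens) for cytotoxicity, read by MTT assay, with a stated time of 24 h (on this read-out higher numbers stand for weaker inhibition and lower numbers for stronger inhibition), compound 1 gives 1010 nM. Compound 2 `CN1C/C(=C\c2ccc(C#N)cc2)C(=O)/C(=C/c2ccccc2F)C1` carries a different core, and the difference between the two cores is not broken down here. In this assay compound 2 gives 810 nM, and compound 1 stands within the scatter of that number. Compound 3 `CN1C/C(=C\c2ccc(F)cc2)C(=O)/C(=C/c2cccc([N+](=O)[O-])c2)C1` arises from compound 1 by one change, (4-fluorophenyl in place of 2-fluorophenyl on a double-bonded chain carbon bound to a double-bonded ring carbon). In this assay compound 3 gives 7160 nM, and the step is a 7.1-fold higher number from compound 1 to compound 3 (0.85 log units; beyond the scatter).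

Compound 4 `CN1C/C(=C\c2ccc(F)cc2)C(=O)/C(=C/c2ccc(C#N)cc2)C1` has not yet been measured. It arises from compound 2 by the same change, (4-fluorophenyl in place of 2-fluorophenyl on a double-bonded chain carbon bound to a double-bonded ring carbon), at the same place. Among the measured compounds shown here, the only measured instance of this change is the step of a 7.1-fold higher number from compound 1 to compound 3 (0.85 log units; beyond the scatter), so the expectation for compound 4 rests on that single pair and is loose. For compound 4 the step from its parent is expected to be a 6.2-fold higher number from compound 2 to compound 4 (0.79 log units; beyond the scatter). In this assay compound 4 is therefore estimated at 5000 nM, with a likely range from 2000 nM to 12000 nM.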

Compound 4, half-maximal inhibitory concentration: 5030 nM
The estimate for compound 4 lay 1.0-fold (0.00 log units) below the measured number; measured number inside the range.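

In this assay, placing 4-fluorophenyl in place of 2-fluorophenyl gives a 6.2-fold higher number from compound 2 to compound 4 (0.79 log units; beyond the scatter), and this step matches the earlier one within the scatter: the same change on two cores in this assay, a 7.1-fold higher number (0.85 log units; beyond the scatter) from compound 1 to compound 3 and a 6.2-fold higher number (0.79 log units; beyond the scatter) from compound 2 to compound 4, 1.1-fold (0.06 log units) apart, within the scatter of two such steps. On these two cores the change therefore carries over, with a higher number and a step of similar size on each. Among the compounds shown here, this rests on only two pairs in a single cell read-out, so it does not show that the step would hold on any other core, and it gives no reason why the number rises.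

The compounds shown leave open whether the step would keep its size with an amine or a carboxylic acid on the aromatic ring in place of the nitrile of compound 2 and compound 4. They also leave open whether it would survive a longer chain in place of the methyl group that all four compounds share.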